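Dropping One Hydroxy Group from a Stilbene Diol

A few compounds are considered here, and "the series" means these few. Any claim that something is new, unique, unknown or untested is made for them only; others in the source may bear on it.

Compound 1 has the structure `Oc1ccc(/C=C/c2ccccc2)cc1O`. In a physicochemical assay for lipophilicity, read by HPLC, measured as octanol-water partition (a higher number here means a more lipophilic compound, a lower number a more polar compound), compound 1 gives "not determined" (no result reported), so no number can be attached to it, and where it stands must be read from its neighbours. Compound 2, with structure `COc1cc(/C=C/c2ccccc2)cc(OC)c1`, gives 4.15 in this assay. Compound 3, with structure `COc1cccc(CCc2ccc(O)cc2)c1`, gives 3.07 in this assay. Compound 4, the one still to be measured, has the structure `Oc1cccc(/C=C/c2ccccc2)c1`.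

Going from compound 1 to compound 4, the change is hydrogen in place of hydroxy on an aromatic carbon; a hydroxy group is removed, leaving a single hydroxy on that ring. Within the data shown here, without a number for compound 1, no measured step can be stated, only an expectation: in this assay the step from compound 1 to compound 4 is expected to go upward, by an amount beyond the usual scatter of repeated measurements. As a guide, compound 2, which carries no hydroxy group at all, gives 4.15 in this assay, and compound 3, carrying one hydroxy group on a more flexible skeleton, gives 3.07.

For compound 4 the estimated value in this assay is 4.1, with an expected range from 3.6 to 4.6.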

Compound 4, partition coefficient: 3.22
Estimate against measurement, compound 4: 0.88 log units above; measured number outside the range, below it.
By their numbers in this assay, from the lowest: compounds 3 and 4 (each within the scatter of the next); then compound 2.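

In this assay, among these compounds, compound 1 has no number to set against compound 4, so no step between them can be read. As far as these compounds go, how far replacing that hydroxy group with hydrogen shifts the value stays open. Nothing shown here offers an explanation for the result.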